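Adding a nitro group: from compound 1 to compound 4

The source may hold more compounds than are shown below. What is called first, only, known or untested is meant among the compounds shown, and "the series" means these compounds.

In a functional assay on U-87MG ATCC cells (Homo sapiens) for cytotoxicity, read by MTT assay, with a stated time of 48 h (a lower number here means a stronger inhibitor, a higher number a weaker inhibitor), compound 1 (`C/C(=N/NC(=S)Nc1ccccc1)c1ccccn1`) gives 1.4 nM, level with compound 2 (`CC(=NNC(=S)Nc1ccccc1)c1ccccn1`) at 1.4 nM. These two share the lowest number measured. The step of no change at the digits printed from compound 1 to compound 2 (within the scatter) concerns only (the fact that one of compounds 1 and 2 is drawn with a defined configuration and the other without, at the place where they differ), so it does not bear on a new substituent. Compound 3 (`C/C(=N/NC(=S)Nc1cccc(I)c1)c1ccccn1`) gives 84 nM. Iodo in place of hydrogen on an aromatic carbon gives a 60-fold higher number from compound 1 to compound 3 (1.78 log units; beyond the scatter), the only measured substituent step and a large one. Compound 4 (`C/C(=N/NC(=S)Nc1ccc([N+](=O)[O-])cc1)c1ccccn1`) carries nitro in place of hydrogen on an aromatic carbon, with nitro in place of hydrogen on an aromatic carbon, para to a large group. On that single precedent, a higher number is expected in this assay, though a smaller rise than with iodo, estimated as an 11-fold higher number from compound 1 to compound 4 (1.03 log units; beyond the scatter). For compound 4 the estimate is 15 nM, with an expected range of 2 nM to 120 nM.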

Compound 4, half-maximal inhibitory concentration: 160 nM
The estimate for compound 4 lay 11-fold (1.03 log units) below the measured number, outside the stated range (above it).
By their numbers in this assay, from the lowest: compounds 1 and 2 (each within the scatter of the next); then compounds 3 and 4 (each within the scatter of the next).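

In this assay nitro on an aromatic carbon para to a large group gives a 110-fold higher number from compound 1 to compound 4 (2.06 log units; beyond the scatter) and so shows that this place on the ring does not take this change without a large rise. Beside a 60-fold higher number from compound 1 to compound 3 (1.78 log units; beyond the scatter) this is a second substituent step in the same direction, so the rise in this series is no longer tied to iodo alone. Nothing measured here bears on the cause of this rise. As far as these compounds go, whether an amine or a methoxy group at this same place stays closer to compound 1 remains open.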